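Swapping Nitro for Chloro in a Potent Inhibitor

The source may hold more compounds than are shown below. What is called first, only, known or untested is meant among the compounds shown, and "the series" means these compounds.

Values measured in a functional assay (aorta) for inhibition, with Oryctolagus cuniculus as the target (a lower number here means a stronger inhibitor, a higher number a weaker inhibitor), are as follows.
Compound 1 `CCO/C(O)=C1\C(C)=NC(=S)N(C(=O)OC(C)C)C1c1ccccc1C(F)(F)F` gives 50 nM
Compound 2 `CCO/C(O)=C1\C(C)=NC(=S)N(C(=O)OC2CCN(Cc3ccccc3)CC2)C1c1ccccc1C(F)(F)F` gives 9 nM
Compound 3 `CC1=NC(=S)N(C(=O)OC2CCN(Cc3ccccc3)CC2)C(c2ccccc2[N+](=O)[O-])/C1=C(\O)OC(C)C` gives 2 nM

Among these three, compound 3 holds the lowest number and is the strongest inhibitor. Its gaps to compound 2, the nearest, and to compound 1, the furthest, both lie beyond the scatter.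

Compound 4 `CC1=NC(=S)N(C(=O)OC2CCN(Cc3ccccc3)CC2)C(c2ccccc2Cl)/C1=C(\O)OC(C)C` has not yet been measured in this assay and departs from compound 3 in one place: chloro in place of nitro on an aromatic carbon. This is chloro in place of nitro on an aromatic carbon of a six-membered aromatic ring of carbon only, ortho to a large group, so 2-nitrophenyl becomes 2-chlorophenyl.

For the measured compounds named here, no measured pair isolates this change, so the evidence is indirect. Compound 2 has neither nitro nor chloro and differs from compound 3 in more than one place, yet compound 2 still reaches 9 nM in this assay, so a low number does not appear to depend on nitro alone. A modest move toward a higher number, meaning a weaker inhibitor, therefore seems likely. The expected step is a 2.5-fold higher number from compound 3 to compound 4 (0.40 log units; beyond the scatter) and it remains only an estimate. Compound 4 is estimated at 5 nM with 1.5 nM to 18 nM as the expected range.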

Compound 4, half-maximal inhibitory concentration: 5 nM
Compound 4: middle estimate and measured number agree at the digits printed; measured number inside the range.
By their numbers in this assay, from the lowest: compound 3; then compounds 4 and 2 (each within the scatter of the next); then compound 1.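

For the compounds shown here, this pair is the first to differ in one place only, so it gives a direct reading of a change on an aromatic carbon of a six-membered aromatic ring of carbon only, ortho to a large group. In this assay, going from 2-nitrophenyl to 2-chlorophenyl costs a 2.5-fold higher number from compound 3 to compound 4 (0.40 log units; beyond the scatter), a modest step that lies beyond the scatter. Nitro is therefore not required for a low number at this place, as compound 4, carrying chloro with no nitro anywhere in the structure, still gives 5 nM, although compound 3 remains the stronger inhibitor of the two. Nothing shown here offers an explanation for the size of this step.

The compounds shown contain no pair that sets trifluoromethyl against nitro or chloro with everything else unchanged, so the standing of these three groups relative to one another at this place remains open. From the compounds shown here alone, it is also open what a methoxy group, a nitrile or an amine would give there, and whether the nitro-to-chloro step keeps its size with a different group on the rest of the molecule.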